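Methyl for hydrogen on the aryl ring of a tetrazole hydrazone

The source may report more compounds than this note shows. Statements on the series, on what has been measured and on what is new or still open speak of the compounds shown alone.

Measured compounds:
- compound 1, `Cn1nnnc1SCC(=O)N/N=C/c1ccccc1`: 9700000 nM
- compound 2, `Cn1nnnc1SCC(=O)N/N=C/c1ccc([N+](=O)[O-])cc1`: 9300000 nM
- compound 3, `Cn1nnnc1SCC(=O)N/N=C/c1ccc(O)cc1`: 632000 nM

All three were tested in an ADME assay on NIH3T3 cells (Mus musculus) for cytotoxicity, read by XTT assay, with a stated time of 24 h; a lower number here means a stronger inhibitor, a higher number a weaker inhibitor. Compound 1 gives the highest number of the three. Compound 2 sits within the scatter of it (a 1.0-fold lower number from compound 1 to compound 2 (0.02 log units; within the scatter)), while compound 3 stands well apart (a 15-fold lower number from compound 1 to compound 3 (1.19 log units; beyond the scatter)), and between compound 2 and compound 3 the gap is also large (a 15-fold lower number from compound 2 to compound 3 (1.17 log units; beyond the scatter)).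

Compound 4, `Cc1ccccc1/C=N/NC(=O)CSc1nnnn1C`, is not yet measured. It differs from compound 1 in one place: methyl in place of hydrogen on an aromatic carbon. For the measured compounds named here, no measured step exchanges a hydrogen for a methyl on this ring, so the nearest guide is the pair of substitutions already seen there. The nitro left the number unchanged within the scatter, whereas the hydroxy lowered it strongly. A methyl shares neither feature, so for compound 4 a step of about a 1.2-fold lower number from compound 1 to compound 4 (0.08 log units; within the scatter) is expected, that is, no change beyond the scatter. The estimated value for compound 4 in this assay is 8000000 nM, with a likely range from 3000000 nM to 20000000 nM.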

Compound 4, half-maximal inhibitory concentration: 6320000 nM
Beside the measured number, compound 4's estimate is 1.3-fold (0.10 log units) above it; the measured number falls inside the stated range.
By their numbers in this assay, from the lowest: compound 3; then compounds 4, 2 and 1 (each within the scatter of the next).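

In this assay, methyl in place of hydrogen stays within the scatter, with a 1.5-fold lower number from compound 1 to compound 4 (0.19 log units; within the scatter), and compound 4 is the only compound shown with a group ortho to a large group. For the compounds shown here, the ring therefore now carries two groups, nitro and methyl, whose steps from compound 1 lie within the scatter, while hydroxy remains the only group with a step beyond it, at a 15-fold lower number from compound 1 to compound 3 (1.19 log units; beyond the scatter). No measurement here offers a reason for the methyl result.

On these data alone, whether a longer chain such as ethyl, ortho to a large group, would also stay within the scatter remains open. Also open, as far as these compounds go, is whether an amine or a carboxylic acid in that place would give a step as large as the one seen with hydroxy.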